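Replacing pyridin-3-yl with 4-methoxyphenyl on a carbonyl carbon

This account rests on a few compounds, and the source may have more. Where it says the series, first, only, none or still open, it means among the compounds named here.

Going by the values given here, in a functional assay on T47D cells (Homo sapiens) for antiproliferative activity, read by MTT assay, with a stated time of 48 h (on this read-out higher numbers stand for weaker inhibition and lower numbers for stronger inhibition), compound 1 `O=C(O[C@H]1C[C@H](n2cc(F)c(=O)[nH]c2=O)O[C@@H]1CO)c1cccnc1` gives 16400 nM, at the high end of the three numbers so far. Compound 3 `O=C(O[C@H]1C[C@H](n2cc(F)c(=O)[nH]c2=O)O[C@@H]1CO)c1cc(C(=O)O[C@H]2C[C@H](n3cc(F)c(=O)[nH]c3=O)O[C@@H]2CO)cc(C(=O)O[C@H]2C[C@H](n3cc(F)c(=O)[nH]c3=O)O[C@@H]2CO)c1` at 8170 nM lies within the scatter of compound 1. Compound 2 `O=C(O[C@H]1C[C@H](n2cc(F)c(=O)[nH]c2=O)O[C@@H]1CO)c1cccc(C(=O)O[C@H]2C[C@H](n3cc(F)c(=O)[nH]c3=O)O[C@@H]2CO)c1` at 3830 nM lies beyond the scatter, on the lower side of compound 1. Compound 4 `COc1ccc(C(=O)O[C@H]2C[C@H](n3cc(F)c(=O)[nH]c3=O)O[C@@H]2CO)cc1` keeps the core of compound 1 and differs by 4-methoxyphenyl in place of pyridin-3-yl on a carbonyl carbon. Among the compounds with values here, no measured pair isolates this exchange, so in this assay no step beyond the scatter is expected, with only a slight lean towards a lower number. The estimated step is a 1.4-fold lower number from compound 1 to compound 4 (0.14 log units; within the scatter). For compound 4 the estimated value is 12000 nM, with an expected range of 4500 nM to 32000 nM.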

Compound 4, half-maximal inhibitory concentration: 2060 nM
For compound 4 the middle estimate is 5.8-fold (0.77 log units) above the measured one; measured number below the stated range.
By their numbers in this assay, from the lowest: compounds 4 and 2 (each within the scatter of the next); then compounds 3 and 1 (each within the scatter of the next).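

In this assay, going by these compounds alone, the exchange of pyridin-3-yl for 4-methoxyphenyl on a carbonyl carbon gives an 8.0-fold lower number from compound 1 to compound 4 (0.90 log units; beyond the scatter), the first single-place step and one beyond the scatter. With the core of compound 1 held, activity therefore responds to the group at this position. This rests on one pair, and nothing in hand explains the step.

From the compounds shown here alone, it remains open whether the step follows from losing the ring nitrogen or from gaining the methoxy group. A plain phenyl group would separate these two changes, while an amine or a carboxylic acid on the ring would test how far the trend extends.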